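The source may report more compounds than this note shows. Statements on the series, on what has been measured and on what is new or still open speak of the compounds shown alone.

Measured so far:
compound 1 `N#CC1=C(N)Oc2c(N)cc3nc4ccccc4nc3c2C12C(=O)N(Cc1cnnn1-c1ccc(Cl)cc1Cl)c1ccccc12`; in a functional assay on HCT-116 cells (Homo sapiens) for antiproliferative activity, read by MTT assay, with a stated time of 48 h (on this read-out higher numbers stand for weaker inhibition and lower numbers for stronger inhibition), compound 1 gives > 50000 nM, a limit of the assay.
compound 2 `Cc1cc(C)c(-n2nncc2CN2C(=O)C3(C(C#N)=C(N)Oc4c(N)cc5nc6ccccc6nc5c43)c3ccccc32)c(C)c1`; in this assay compound 2 gives > 50000 nM, a limit of the assay.

Both values sit at the same limit, as the limit of > 50000 nM in this assay, at which 2 of the 2 values shown sit, states, so neither is a number. Going by the values given here, the only measured step, a step that the two limits leave unreadable from compound 1 to compound 2, compares two limits and therefore has no readable size or direction. Compound 2 thus stands at the limit of this assay and nowhere on a numbered scale.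

Compound 3 `N#CC1=C(N)Oc2c(N)cc3nc4ccccc4nc3c2C12C(=O)N(Cc1cnnn1-c1c(Cl)cc(Cl)cc1Cl)c1ccccc12` differs from compound 2 by 2,4,6-trichlorophenyl in place of 2,4,6-trimethylphenyl on an aromatic nitrogen. Among the compounds with values here, the one measured step bears on the same position, the aryl group on the aromatic nitrogen, but as it runs from one limit to another it gives no measure of how much such an exchange moves the read-out. With no readable step to lean on, no change beyond the scatter can be called in either direction; the only thing the two measured compounds show is that both sit at the limit.

Compound 3 is therefore expected to fall again at the limit of this assay, with an estimate of 100000 nM and a range from 30000 nM to 500000 nM. The step expected from compound 2 to compound 3 is a step that the limit leaves unreadable from compound 2 to compound 3, which is no step beyond the scatter.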

Compound 3, half-maximal inhibitory concentration: 12100 nM
Compound 3: middle estimate off by 8.3-fold (0.92 log units), on the high side; measured number outside the range, below it.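

In this assay, the aryl group on the aromatic nitrogen can move the read-out: with 2,4,6-trichlorophenyl in place of 2,4,6-trimethylphenyl there is an at least 4.1-fold lower number from compound 2 to compound 3 (0.61 log units; beyond the scatter). One further chloro in place of hydrogen on an aromatic carbon also suffices, with an at least 4.1-fold lower number from compound 1 to compound 3 (0.61 log units; beyond the scatter), so 2,4-dichlorophenyl and 2,4,6-trichlorophenyl are not equivalent at this position, and the chlorine-bearing compound 1 goes against any simple link between chloro groups and a lower number. Both steps are lower bounds, and the step between the other two compounds cannot be read, because those two compounds sit at the limit: the limit of > 50000 nM in this assay, at which 2 of the 3 values shown sit.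

Going by these compounds, the true size of either step remains open, as does the question of whether three substituents on the aryl ring are enough in themselves, given that the three methyl groups of compound 2 leave it at a limit of the assay, > 50000 nM. Also open, on these data alone, is whether an aryl group carrying three fluoro or three methoxy groups would hold, raise or lower the number of compound 3, 12100 nM.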